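Swapping the Aryl Group on the Sulfonyl Sulfur

A few compounds are considered here, and "the series" means these few. Any claim that something is new, unique, unknown or untested is made for them only; others in the source may bear on it.

Three compounds share a core in which a bromobenzyl amine is joined through a six-carbon chain to a sulfonamide, and they differ only in the aryl group attached to the sulfonyl sulfur. In a functional assay on MIA PaCa-2 cells (Homo sapiens) for inhibition, read by MTT assay, with a stated time of 72 h (a lower number here means a stronger inhibitor of growth, a higher number a weaker inhibitor of growth), compound 1 `O=[N+]([O-])c1ccc(S(=O)(=O)NCCCCCCNCc2ccc(Br)cc2)cc1` gives 9800 nM. Compound 2 `O=S(=O)(NCCCCCCNCc1ccc(Br)cc1)c1ccc2c(c1)OCC2` gives 13000 nM in this assay, and compound 3 `CC(C)c1ccc(S(=O)(=O)NCCCCCCNCc2ccc(Br)cc2)cc1` gives 5730 nM. Compound 3 stands at the low end of the three numbers, yet one of its two gaps is only a 1.7-fold lower number from compound 1 to compound 3 (0.23 log units; within the scatter), while the other is a 2.3-fold lower number from compound 2 to compound 3 (0.36 log units; beyond the scatter).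

Compound 4 `Cc1ccc(C)c(S(=O)(=O)NCCCCCCNCc2ccc(Br)cc2)c1` is not yet measured. The change from compound 3 is 2,5-dimethylphenyl in place of 4-isopropylphenyl on a sulfonyl sulfur. The measured steps that bear on it are the earlier swaps at the same place: a 1.3-fold higher number from compound 1 to compound 2 (0.12 log units; within the scatter), a 1.7-fold lower number from compound 1 to compound 3 (0.23 log units; within the scatter) and a 2.3-fold lower number from compound 2 to compound 3 (0.36 log units; beyond the scatter). Every one of these swaps gave a small step, so there is no sign in these data of a large move in either direction. Compound 4 is therefore expected to land close to compound 3, with an estimated step of a 1.2-fold higher number from compound 3 to compound 4 (0.09 log units; within the scatter), which is not expected to pass beyond the scatter. The estimate for compound 4 in this assay is 7000 nM, with a range from 3000 nM to 16000 nM.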

Compound 4, concentration for 50% growth inhibition: 12000 nM
Compound 4: the middle estimate sits 1.7-fold (0.23 log units) below what was measured, and the stated range covers the measured number.
By their numbers in this assay, from the lowest: compounds 3, 1, 4 and 2 (each within the scatter of the next, the first and the last beyond it).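

In this assay, putting 2,5-dimethylphenyl in place of 4-isopropylphenyl on the sulfonyl sulfur gives a 2.1-fold higher number from compound 3 to compound 4 (0.32 log units; beyond the scatter) and is the second swap at this position to pass beyond the scatter, so compound 3 now stands apart from two of the three other aryl groups, though still not from the 4-nitrophenyl group of compound 1. The new group itself does not separate from the two weaker-scoring neighbours, with a 1.1-fold lower number from compound 2 to compound 4 (0.03 log units; within the scatter) and with a 1.2-fold higher number from compound 1 to compound 4 (0.09 log units; within the scatter) as well, so at this position three quite different aryl groups give numbers that cannot be told apart, and only the 4-isopropylphenyl group shows any distance from some of them. Nothing measured here offers a reason for this pattern.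

The swap from compound 3 to compound 4 replaces one isopropyl with two methyl groups and moves the substitution on the ring at the same time, so a single methyl or a tert-butyl group on the aromatic ring would be needed to tell those two changes apart. Also open, going by these compounds, is whether a carboxylic acid or an amine on that ring, or a shorter chain in the linker, would shift the number by more than these small steps.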